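The compounds below may be only part of what the source reports. "The series", "measured", "known", "first", "only" and "open" are said of these compounds alone.

Working notes on the series.

Compound 1 `O=C(O)CCCCCCCCC/C=C(/c1ccccc1)c1cccnc1` gives 520 nM in an assay (Equus caballus) for inhibition of Thromboxane-A synthase (Homo sapiens), using microsomes (on this read-out lower numbers stand for stronger inhibition and higher numbers for weaker inhibition), the highest of the two numbers recorded so far. Its nearest neighbour is compound 2 `O=C(O)CCCCCCCCC/C=C(\c1ccccc1)c1cccnc1`, which gives 55 nM; the step of a 9.5-fold lower number from compound 1 to compound 2 (0.98 log units; beyond the scatter) rests on the fact that compounds 1 and 2 differ only in the configuration as drawn alone.

Compound 3 `CC(C)(CCCC/C=C(/c1ccccc1)c1cccnc1)C(=O)O` has not been measured. Against compound 1 the change is 1-carboxy-1-methylethyl in place of 5-carboxypentyl on a saturated chain carbon, four bonds along the chain from a double-bonded chain carbon, with the configuration of the double bond kept as drawn in compound 1. Among the compounds with values here, no measured step touches the carboxylic-acid chain: the one step in hand concerns only configuration, so it offers no direct guide to shortening the chain or to placing two methyl groups on the carbon bearing the carboxylic acid. The expectation therefore rests on compound 1 itself, and the step is estimated as a 3.8-fold higher number from compound 1 to compound 3 (0.59 log units; beyond the scatter), beyond the scatter and toward weaker inhibition. For compound 3 the expected value is 2000 nM, with a range from 400 nM to 10000 nM.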

Compound 3, half-maximal inhibitory concentration: 38 nM
The estimate for compound 3 lay 53-fold (1.72 log units) above the measured number, outside the stated range (below it).
By their numbers in this assay, from the lowest: compounds 3 and 2 (each within the scatter of the next); then compound 1.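

In this assay the replacement of 5-carboxypentyl by 1-carboxy-1-methylethyl gives a 14-fold lower number from compound 1 to compound 3 (1.14 log units; beyond the scatter) with the configuration of the double bond kept as drawn in compound 1. This shows that the read-out responds to the carboxylic-acid chain as well as to configuration, and that the change at this saturated chain carbon moves it toward stronger inhibition. No available evidence accounts for this step.

The compounds shown do not separate the effect of the shorter chain from that of the two methyl groups on the carbon bearing the carboxylic acid, which an unbranched carboxyalkyl chain of the same reach would address. They also leave open how the double-bond isomer of compound 3 would read, and whether a tetrazole or a primary amide could stand in place of the carboxylic acid.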